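The source may hold more compounds than are shown below. What is called first, only, known or untested is meant among the compounds shown, and "the series" means these compounds.

Measured compounds:
Compound 1 `C/C=C\C(=O)Nc1cc(Nc2nccc(-c3cn(C)c4ccccc34)n2)c(OC)cc1N(C)CCN(C)C` gives 660 nM in a functional assay on A549 cells (Homo sapiens) for antiproliferative activity, read by MTT assay, with a stated time of 72 h; a lower number here means a stronger inhibitor, a higher number a weaker inhibitor.
Compound 2 `COc1cc(N(C)CCN(C)C)c(NC(=O)C=C(C)C)cc1Nc1nccc(-c2cn(C)c3ccccc23)n1` gives 4100 nM in this assay.
Compound 3 `CCC/C=C\C(=O)Nc1cc(Nc2nccc(-c3cn(C)c4ccccc34)n2)c(OC)cc1N(C)CCN(C)C` gives 808 nM in this assay.

Compound 3 stands second highest of the three numbers in this assay; its nearest neighbour is compound 1, a step of a 1.2-fold higher number from compound 1 to compound 3 (0.09 log units; within the scatter), while compound 2 lies furthest away, with a 5.1-fold lower number from compound 2 to compound 3 (0.71 log units; beyond the scatter). The change from compound 1 to compound 2 was a 6.2-fold higher number from compound 1 to compound 2 (0.79 log units; beyond the scatter). All three measured steps concern the acyl group on the carbonyl carbon.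

Compound 4 `CCC/C=C\C(=O)Nc1cc(Nc2ncc(C#N)c(-c3cn(C)c4ccccc34)n2)c(OC)cc1N(C)CCN(C)C` differs from compound 3 in another place: cyano in place of hydrogen on an aromatic carbon. For the measured compounds named here, none of the measured steps touches this part of the shared core, so no measured step bears on the change, and its size and direction cannot be read from the numbers at hand. The account therefore expects the step from compound 3 to compound 4 to be a 1.6-fold lower number from compound 3 to compound 4 (0.21 log units; within the scatter), with wide uncertainty. Compound 4 is estimated at 500 nM in this assay, within a range of 120 nM to 2500 nM.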

Compound 4, half-maximal inhibitory concentration: 166 nM
For compound 4 the middle estimate is 3.0-fold (0.48 log units) above the measured one, within the range that was stated.
By their numbers in this assay, from the lowest: compound 4; then compounds 1 and 3 (each within the scatter of the next); then compound 2.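

In this assay putting cyano on this aromatic carbon, ortho to a 1-methyl-1H-indol-3-yl group, gives a 4.9-fold lower number from compound 3 to compound 4 (0.69 log units; beyond the scatter) and shows that the number responds to a change at this place in the shared core. For the compounds shown here, the earlier steps concerned only the group on the carbonyl carbon, so this is the first measured sign that a small group of 2 heavy atoms on the six-membered aromatic ring with 2 nitrogen can lower the number beyond the scatter. Nothing measured here accounts for this step.

Going by these compounds, whether the same carbon would respond similarly to a chlorine atom, a methyl group or a carboxamide remains open. Also open, on these data alone, is whether cyano would lower the number in the same way with the prop-1-en-1-yl or the 2-methylprop-1-en-1-yl group on the carbonyl carbon.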